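This account rests on a few compounds, and the source may have more. Where it says the series, first, only, none or still open, it means among the compounds named here.

Series notes. Compound 1 `CC(C)Nc1nc(NCc2ccco2)c2ccccc2n1` is the unsubstituted parent; in a physicochemical assay for solubility, at pH 2 (a higher number here means a more soluble compound, a lower number a less soluble compound), compound 1 returns >= 30000 nM, a limit of the assay rather than a number. Compound 2 `CC(C)Nc1nc(NCc2ccco2)c2c(Cl)cccc2n1` is its chloro analogue; in this assay compound 2 likewise returns >= 30000 nM, again a limit. The step that the two limits leave unreadable from compound 1 to compound 2 is consequently not readable, both values sitting at the limit of >= 30000 nM in this assay, at which 2 of the 2 values shown sit. Compound 2 thus stands at the upper edge of what this assay reports, with no number beneath it.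

Compound 3 `Cc1cccc2nc(NC(C)C)nc(NCc3ccco3)c12` differs from compound 2 by methyl in place of chloro on an aromatic carbon. Going by the values given here, the single measured step, a step that the two limits leave unreadable from compound 1 to compound 2, gives no readable size, so no direction can be drawn from it; the expectation is simply that compound 3 stays where compound 2 sits. For compound 3 a solubility of 30000 nM is estimated, with a range of 12000 nM to 60000 nM, most likely reported again as a limit. The step from compound 2 to compound 3 is therefore expected to be a number no higher from compound 2 to compound 3 (the limit leaves the size open), nothing beyond the scatter.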

Compound 3, solubility: >= 30000 nM
Compound 3 ended at the assay's limit; the forecaster's own chance of this, stated with the estimate: 80%; the middle value sits exactly at the limit.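

Going by these compounds alone, no step among compound 1, compound 2 and compound 3 can be read in this assay, as all three sit at the same limit: the limit of >= 30000 nM in this assay, at which 3 of the 3 values shown sit. The compounds shown leave open the actual solubility of each, and so whether hydrogen, chloro or methyl on this aromatic carbon makes any difference.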